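The source may report more compounds than this note shows. Statements on the series, on what has been measured and on what is new or still open speak of the compounds shown alone.

Series notes. Compound 1 `Cc1ccc2[nH]c(-c3ccc(-c4ccc(-c5cccc(Cl)c5)cc4)cc3)nc2c1` gives 2800 nM in a functional assay on A549 cells (Homo sapiens) for inhibition, read by sulforhodamine B assay; on this read-out lower numbers stand for stronger inhibition of growth and higher numbers for weaker inhibition of growth. Compound 2 `COc1ccc(-c2ccc(-c3ccc(-c4nc5cc(C)ccc5[nH]4)cc3)cc2)cc1OC` gives 2100 nM in this assay; the step of a 1.3-fold lower number from compound 1 to compound 2 (0.12 log units; within the scatter) accompanies the change (3,4-dimethoxyphenyl in place of 3-chlorophenyl on an aromatic carbon). Compound 3 `Clc1cccc(-c2ccc(-c3ccc(-c4nc5ccccc5[nH]4)cc3)cc2)c1` gives 31100 nM in this assay, the highest of the three measured numbers; the step of an 11-fold higher number from compound 1 to compound 3 (1.05 log units; beyond the scatter) accompanies the core difference (hydrogen in place of methyl on an aromatic carbon). Compound 4 `COc1ccc(-c2ccc(-c3ccc(-c4nc5ccccc5[nH]4)cc3)cc2)cc1OC` is not yet measured in this assay. It differs from compound 3 by 3,4-dimethoxyphenyl in place of 3-chlorophenyl on an aromatic carbon, the same change as that between compound 1 and compound 2, with the place described in identical words. For compound 4 the expected step is a 1.3-fold lower number from compound 3 to compound 4 (0.11 log units; within the scatter), set beside the measured 1.3-fold lower number from compound 1 to compound 2 (0.12 log units; within the scatter), because that earlier step a 1.3-fold lower number from compound 1 to compound 2 (0.12 log units; within the scatter) lay within the scatter, so only a small shift on the core of compound 3 is anticipated. Compound 4 is therefore expected to give 24000 nM, estimated between 10000 nM and 60000 nM.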

Compound 4, concentration for 50% growth inhibition: 7600 nM
The estimate for compound 4 lay 3.2-fold (0.50 log units) above the measured number, and the stated range ends above it.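

In this assay the new step of a 4.1-fold lower number from compound 3 to compound 4 (0.61 log units; beyond the scatter) shows that the size of the change to 3,4-dimethoxyphenyl depends on the core: the same change on two cores in this assay, a 1.3-fold lower number (0.12 log units; within the scatter) from compound 1 to compound 2 and a 4.1-fold lower number (0.61 log units; beyond the scatter) from compound 3 to compound 4, 3.1-fold (0.49 log units) apart, beyond the scatter of two such steps. The step to hydrogen in place of methyl, a 3.6-fold higher number from compound 2 to compound 4 (0.56 log units; beyond the scatter), raises the number on both pairs but by different amounts: the same change on two cores in this assay, an 11-fold higher number (1.05 log units; beyond the scatter) from compound 1 to compound 3 and a 3.6-fold higher number (0.56 log units; beyond the scatter) from compound 2 to compound 4, 3.1-fold (0.49 log units) apart, beyond the scatter of two such steps. These four compounds show that the two changes do not add up independently here, but they do not show why, nor how either change would behave on any further core.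

Open, as far as these compounds go, is how an amine or a carboxylic acid in place of 3-chlorophenyl would behave on either core. Also open, from the compounds shown here alone, is whether a longer chain in place of the methyl would keep the lower numbers of compound 1 and compound 2.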